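Sulfonyl to Carboxamide Swap on the Aryl Ring

The source may report more compounds than this note shows. Statements on the series, on what has been measured and on what is new or still open speak of the compounds shown alone.

Measured so far:
- compound 1 `CCN(CC)S(=O)(=O)c1ccc(S(=O)(=O)N2CCC[C@@H](C(=O)N[C@H]3CC[C@H](OC)CC3)C2)cc1`: 2000 nM
- compound 2 `O=C([C@@H]1CCCN(S(=O)(=O)c2ccc(S(=O)(=O)C3CCC3)cc2)C1)N1CCC(F)(F)CC1`: 78 nM

In a functional assay on BXPC-3 cells (Homo sapiens) for inhibition, read by MTT assay, with a stated time of 7 days (on this read-out lower numbers stand for stronger inhibition and higher numbers for weaker inhibition), compound 2 gives 78 nM and stands lowest of the two numbers, with compound 1 at 2000 nM a good deal higher, beyond the scatter. Compound 3 `CCN(CC)C(=O)c1ccc(S(=O)(=O)N2CCC[C@@H](C(=O)N3CCC(F)(F)CC3)C2)cc1` differs from compound 2 by diethylcarbamoyl in place of cyclobutylsulfonyl on an aromatic carbon. Within the data shown here, no step between measured compounds shows what this change does. The move is expected to cost some potency, estimated as a 2.6-fold higher number from compound 2 to compound 3 (0.41 log units; beyond the scatter), a modest weakening rather than a drastic one. Compound 3 is therefore expected at 200 nM, in the range 50 nM to 800 nM.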

Compound 3, half-maximal inhibitory concentration: 240 nM
For compound 3 the middle estimate is 1.2-fold (0.08 log units) below the measured one; the range from low to high includes it.
By their numbers in this assay, from the lowest: compound 2; then compound 3; then compound 1.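

In this assay, putting diethylcarbamoyl in place of cyclobutylsulfonyl gives a 3.1-fold higher number from compound 2 to compound 3 (0.49 log units; beyond the scatter) and so a modest loss. At this aromatic carbon, para to a large group, activity therefore does not depend on the cyclobutylsulfonyl group, although compound 2 keeps the lower number. Nothing measured here accounts for the step. Still open, as far as these compounds go, is how a carboxylic acid, a primary amine or a methylsulfonyl group would fare at this position. Whether a cyclic carbamoyl group such as pyrrolidine-1-carbonyl would narrow the gap to compound 2 also remains unanswered.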